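This account rests on a few compounds, and the source may have more. Where it says the series, first, only, none or still open, it means among the compounds named here.

In an ADME assay (liver) for metabolic stability, with Liver microsome (Rattus norvegicus) as the target, using microsomes and NADPH, with a stated time of 30 min, at 37 degrees C, tested at 1 uM (on this read-out higher numbers stand for fast clearance and lower numbers for slow clearance), the measured compounds stand as follows:

compound 1 `CC(O)(c1ccc(-c2ccc(S(=O)(=O)c3ccc(N)nc3)nc2Nc2cccnc2)nc1)C(F)(F)F`: 142 mL.min-1.g-1
compound 2 `CC(O)(c1ccc(-c2ccc(S(=O)(=O)c3ccc(N)nc3)nc2Nc2ccccn2)nc1)C(F)(F)F`: 130 mL.min-1.g-1
compound 3 `CC(O)(c1ccc(-c2ncc(S(=O)(=O)c3ccc(N)nc3)s2)c(Cl)c1)C(F)(F)F`: < 14 mL.min-1.g-1 (a limit of the assay, not a number)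

Compound 3 is known only through its limit, < 14 mL.min-1.g-1, and that limit sits at the low end of the numbers shown. Compounds 1 and 2 lie far up the scale from it.

The next compound to be read is compound 4 `C[C@@](O)(c1ccc(-c2ncc(S(=O)(=O)c3ccc(N)nc3)s2)c(Cl)c1)C(F)(F)F`. The change from its parent is purely one of drawn configuration: the two compounds have the same atoms and bonds; at least one stereo element is drawn with a configuration in one of them and without one in the other: 1 of 1 stereo elements differ; a stereocentre at a saturated chain carbon is drawn without a configuration in compound 3 and R in compound 4. Among the compounds with values here, no measured step tests a stereocentre. Within the data shown here, the only step on record is a 1.1-fold lower number from compound 1 to compound 2 (0.04 log units; within the scatter), which concerns a different change on a different scaffold and stays within the scatter, so it offers no direct guide here. With the same atoms and bonds on both sides and no data pointing to a shift, no step beyond the scatter is expected in this assay, although the parent's limit leaves its true number open. The expected step is a step that the limit leaves unreadable from compound 3 to compound 4. It may be that compound 4 too will give only a limit. For compound 4 the estimate is 12 mL.min-1.g-1, with an expected range from 5 mL.min-1.g-1 to 30 mL.min-1.g-1.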

Compound 4, intrinsic clearance in microsomes: < 14 mL.min-1.g-1
Compound 4: only a limit was reported; the forecaster's own chance of this, stated with the estimate: 65%; the middle value does not contradict the limit.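

In this assay, no step can be read between compound 3 and compound 4, because each of the two is reported only as a limit and not as a number: the limit of < 14 mL.min-1.g-1 in this assay, at which 2 of the 4 values shown sit.

The compounds shown leave open what the true clearance numbers of compound 3 and compound 4 are, and whether the R configuration drawn in compound 4 makes any difference to them.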